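This account rests on a few compounds, and the source may have more. Where it says the series, first, only, none or still open, it means among the compounds named here.

Going by the values given here, in an ADME assay on MT4 cells (Homo sapiens) for cytotoxicity, read by MTT assay, with a stated time of 5 days (on this read-out higher numbers stand for lower toxicity in this test and lower numbers for higher toxicity in this test), compound 2 `Cc1cc(C)c(Oc2cc(Nc3ccc(C#N)cc3)ncc2C(=O)NCc2cn(CCC#N)nn2)c(C)c1` gives 40200 nM, the higher of the two numbers measured so far, the other belonging to compound 1 `COC(=O)Cn1cc(CNC(=O)c2cnc(Nc3ccc(C#N)cc3)cc2Oc2c(C)cc(C)cc2C)nn1`, which in this assay gives 13800 nM. Among the compounds with values here, the single measured step at this position, a 2.9-fold higher number from compound 1 to compound 2 (0.46 log units; beyond the scatter), was modest. Compound 3 `Cc1cc(C)c(Oc2cc(Nc3ccc(C#N)cc3)ncc2C(=O)NCc2cn(Cc3ccc([N+](=O)[O-])cc3)nn2)c(C)c1` differs from compound 2 by 4-nitrophenyl in place of cyanomethyl on a saturated chain carbon bound to an aromatic nitrogen. Within the data shown here, with only one step at this position to go on, and a different group entering, a shift of similar size in either direction seems possible, so no step beyond the scatter is confidently expected. Compound 3 is therefore estimated at 30000 nM, with a range of 10000 nM to 90000 nM, the expected step being a 1.3-fold lower number from compound 2 to compound 3 (0.13 log units; within the scatter).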

Compound 3, half-maximal cytotoxic concentration: >= 139000 nM
Compound 3 gave a limit, no number; the forecaster's own chance of this, stated with the estimate: 10%; middle value at least 4.6-fold (0.66 log units) from the limit.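

In this assay compound 3 gives a limit of the assay and not a number: the limit of >= 139000 nM in this assay, at which 1 of the 3 values shown sits. Even so, the steps can be read as an at least 3.4-fold higher number from compound 2 to compound 3 (0.53 log units; beyond the scatter) and as an at least 10-fold higher number from compound 1 to compound 3 (1.00 log units; beyond the scatter). This position therefore carries a 4-nitrophenyl with its aromatic ring, which neither earlier compound holds here, without any fall in the number.

As far as these compounds go, how far the true value of compound 3 lies past its limit stays open. Also open, from the compounds shown here alone, is whether the change follows the aromatic ring itself or its nitro group, and how an amine or a carboxylic acid on that ring would read.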